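The compounds below may be only part of what the source reports. "The series", "measured", "known", "first", "only" and "open" are said of these compounds alone.

Working notes on the series. All three measured compounds share one core and differ only in the group on the saturated chain carbon bound to an aromatic nitrogen. In an assay on isolated protein for inhibition of aldehyde dehydrogenase 1A1 (Homo sapiens), read by spectrophotometry, tested at 10 uM (on this read-out lower numbers stand for less inhibition and higher numbers for more inhibition at the one concentration tested (going by the name of the read-out)), compound 1 `O=C(C1CC1)N1CCN(Cc2nc3ccccc3n2Cc2ccccc2F)CC1` gives 40.7%. Compound 2 `O=C(C1CC1)N1CCN(Cc2nc3ccccc3n2Cc2ccc(F)cc2)CC1` gives 32.7% in this assay, and compound 3 `O=C(C1CC1)N1CCN(Cc2nc3ccccc3n2Cc2ccccc2)CC1` gives 23.9%. Moving the fluoro gives a number 8 percentage points lower from compound 1 to compound 2 (within the scatter). Removing it gives a number 16.8 percentage points lower from compound 1 to compound 3 (beyond the scatter) and a number 8.8 percentage points lower from compound 2 to compound 3 (within the scatter), so compound 3 sits within the scatter of compound 2 but separated from compound 1 by a step beyond the scatter.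

Compound 4 `CC(C)Cn1c(CN2CCN(C(=O)C3CC3)CC2)nc2ccccc21` is not yet measured. It differs from compound 3 thus: isopropyl in place of phenyl on a saturated chain carbon bound to an aromatic nitrogen. None of the recorded steps swaps the phenyl for an alkyl group; they only alter the fluoro pattern on that same position, and all three stay within or just beyond the scatter. Varying this group therefore moves this assay only modestly on the evidence at hand, and the step from compound 3 to compound 4 is expected to be of that kind, leaning toward a small decrease or none beyond the scatter, a number 3.9 percentage points lower from compound 3 to compound 4 (within the scatter). Compound 4 is estimated at 20%, with a range from 5% to 38%.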

Compound 4, a percentage reported as inhibition, at one concentration (the size of the read-out at that concentration, not a potency): 13.1%
Compound 4: middle estimate off by 6.9 percentage points, on the high side; the range from low to high includes it.
By their numbers in this assay, from the lowest: compound 4; then compounds 3, 2 and 1 (each within the scatter of the next, the first and the last beyond it).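

Isopropyl in place of phenyl on a saturated chain carbon bound to an aromatic nitrogen gives the first step beyond the scatter in this assay that starts from compound 3 (a number 10.8 percentage points lower from compound 3 to compound 4 (beyond the scatter)), whereas the fluoro changes showed a step of that kind only between compound 1 and compound 3. The same change starting from the fluorinated phenyl groups gives larger steps (a number 19.6 percentage points lower from compound 2 to compound 4 (beyond the scatter); a number 27.6 percentage points lower from compound 1 to compound 4 (beyond the scatter)), so compound 4 stands lowest of the four, beyond the scatter of each of the others, and this position responds to more than the fluoro pattern. No measurement at hand speaks to what lies behind these steps.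

With isopropyl as the only alkyl group shown, it stays open whether a cyclohexyl ring or a longer chain such as n-pentyl at this position would read with the phenyl compounds or with compound 4. Going by these compounds, it is equally open whether a 2-chlorophenyl or a pyridyl group would extend the higher end set by compound 1 (40.7%), and all of this rests on the shared core alone.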